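Diaryl urea series: swapping methyl for trifluoromethyl

A few compounds are considered here, and "the series" means these few. Any claim that something is new, unique, unknown or untested is made for them only; others in the source may bear on it.

Compound 1 `COc1cc2cc(Oc3ccc(NC(=O)Nc4ccccc4)cc3)c(C)nc2cc1OC` and compound 2 `COc1cc2cc(Oc3ccc(NC(=O)Nc4ccc(C)cc4)cc3)c(C)nc2cc1OC` share one core. In a functional assay on IGROV-1 cells (Homo sapiens) for inhibition, read by sulforhodamine B assay, with a stated time of 48 h, tested at 10 uM (on this read-out lower numbers stand for a stronger effect and higher numbers for a weaker effect at the one concentration tested), compound 1 gives 103%, and compound 2 gives 101%; the step of a number 2 percentage points lower from compound 1 to compound 2 (within the scatter) leaves both within the scatter of each other, and neither differs from the other in any reliable way. Compound 3 `COc1cc2cc(Oc3ccc(NC(=O)Nc4ccc(C(F)(F)F)cc4)cc3)c(C)nc2cc1OC` is not yet measured; it differs from compound 2 by trifluoromethyl in place of methyl on an aromatic carbon. Among the measured compounds shown here, only the step from compound 1 to compound 2 bears on it, a change on an aromatic carbon, and it was small. A step of a number 3 percentage points lower from compound 2 to compound 3 (within the scatter) is therefore expected, nothing beyond the scatter. Compound 3 is estimated at 98%, between 82% and 112%.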

Compound 3, a percentage reported as activity, at one concentration (the size of the read-out at that concentration, not a potency): 71.9%
The estimate for compound 3 lay 26.1 percentage points above the measured number; measured number below the stated range.
By their numbers in this assay, from the lowest: compound 3; then compounds 2 and 1 (each within the scatter of the next).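

This position, on a six-membered aromatic ring of carbon only and para to a large group, does respond to what sits on it in this assay. Methyl did not separate from hydrogen, but trifluoromethyl gives a number 29.1 percentage points lower from compound 2 to compound 3 (beyond the scatter) and a number 31.1 percentage points lower from compound 1 to compound 3 (beyond the scatter), so the outcome depends on the group placed there. Nothing measured here explains this difference. From the compounds shown here alone, whether a chlorine atom, a nitrile or a methoxy group at this position would also lower the number remains open. So does whether trifluoromethyl would have the same effect elsewhere on this ring.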